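Acetoxy to hydroxymethyl, repeated on a second core

The source may hold more compounds than are shown below. What is called first, only, known or untested is meant among the compounds shown, and "the series" means these compounds.

Compound 1 `CC(=O)OCCS(=O)(=O)c1ccc(S(N)(=O)=O)s1` and compound 2 `NS(=O)(=O)c1ccc(S(=O)(=O)CCCO)s1` share one core and differ in one place: hydroxymethyl in place of acetoxy on a saturated chain carbon, two bonds along the chain from a sulfonyl sulfur. In a physicochemical assay for solubility, at pH 7.4 (on this read-out lower numbers stand for lower solubility and higher numbers for higher solubility), compound 1 gives 880 ug/mL, and compound 2 gives 14600 ug/mL, so the change made a 17-fold higher number from compound 1 to compound 2 (1.22 log units; beyond the scatter).

Compound 3 `CC(=O)OCCCCc1ccc(S(N)(=O)=O)cc1` carries the acetoxy group on a different core; the difference between the two cores is not broken down here. In this assay compound 3 gives 800 ug/mL, which sits within the scatter of the number for compound 1.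

Compound 4 `NS(=O)(=O)c1ccc(CCCCCO)cc1` is related to compound 3 by hydroxymethyl in place of acetoxy on a saturated chain carbon, four bonds along the chain from an aromatic carbon. For the measured compounds named here, this is the same kind of change as the one from compound 1 to compound 2, but not the same change: there the place is two bonds along the chain from a sulfonyl sulfur, here it is four bonds along the chain from an aromatic carbon, and the chain hangs from a different core.

Going by the values given here, the only measured instance of this kind of change is the large step of a 17-fold higher number from compound 1 to compound 2 (1.22 log units; beyond the scatter), and compound 3 starts close to compound 1, so for compound 4 a step of a 10-fold higher number from compound 3 to compound 4 (1.00 log units; beyond the scatter) is expected, held somewhat short of the measured one since the place and the core differ. Compound 4 is therefore estimated at 8000 ug/mL, with a range from 3000 ug/mL to 20000 ug/mL expected.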

Compound 4, solubility: 2600 ug/mL
Compound 4: middle estimate off by 3.1-fold (0.49 log units), on the high side, and the stated range ends above it.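

In this assay the replacement of acetoxy by hydroxymethyl gives a higher number on both cores: a 3.3-fold higher number from compound 3 to compound 4 (0.51 log units; beyond the scatter) on the second core, set against a 17-fold higher number from compound 1 to compound 2 (1.22 log units; beyond the scatter) on the first, and both steps lie beyond the scatter. The direction of the change therefore carries from one core to the other in these two pairs, but the size does not carry in full, since the first step is large and the second modest, and two pairs cannot show whether the core or the place of the change sets that size, as the place is two bonds along the chain from a sulfonyl sulfur in one pair and four bonds along the chain from an aromatic carbon in the other. Nothing available here accounts for the difference in size between the two steps.

Still open, going by these compounds, is whether a carboxylic acid or an amine at the end of the chain would follow the same direction as hydroxymethyl on either core. Also open, on these data alone, is how the step behaves on a longer chain, where the place of the change moves again while the core stays the same.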